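The source may report more compounds than this note shows. Statements on the series, on what has been measured and on what is new or still open speak of the compounds shown alone.

Measured in a functional assay on HCT-116 cells (Homo sapiens) for cytotoxicity; a higher number here means a weaker inhibitor, a lower number a stronger inhibitor:
Compound 1 `C=CC[C@@H](C[C@@H](C[C@@H](C[C@@H](C[C@@H](C[C@@H](C[C@@H](C[C@H](OC)/C(C)=C/CCCCC)OC)OC)OC)OC)OC)OC)OC` gives 106000 nM
Compound 2 `C=CC[C@@H](C[C@@H](C[C@@H](C[C@@H](C[C@@H](C[C@@H](C[C@@H](C[C@@H](C[C@H](OC)/C(C)=C/CCCCC)OC)OC)OC)OC)OC)OC)OC)OC` gives 86000 nM
Compound 3 `C=CC[C@@H](C[C@@H](C[C@@H](C[C@@H](C[C@@H](C[C@@H](C[C@@H](C[C@@H](C[C@@H](C[C@H](OC)/C(C)=C/CCCCC)OC)OC)OC)OC)OC)OC)OC)OC)OC` gives 75000 nM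

Compound 3 at 75000 nM stands within the scatter of both other compounds, so the three values do not separate. Compound 4 `C=CC[C@@H](C[C@@H](C[C@@H](C[C@@H](C[C@@H](C[C@@H](C[C@@H](C[C@@H](C[C@@H](C[C@@H](C[C@H](OC)/C(C)=C/CCCCC)OC)OC)OC)OC)OC)OC)OC)OC)OC)OC` differs from it by 1-methoxybut-3-en-1-yl in place of vinyl on a saturated chain carbon, two bonds along the chain from an oxygen on a saturated carbon. The same change was measured twice, as a 1.2-fold lower number from compound 1 to compound 2 (0.09 log units; within the scatter) and as a 1.1-fold lower number from compound 2 to compound 3 (0.06 log units; within the scatter), and applied twice over it gave a 1.4-fold lower number from compound 1 to compound 3 (0.15 log units; within the scatter) in the same assay. No step beyond the scatter is therefore expected in this assay here. The expected step is a 1.1-fold lower number from compound 3 to compound 4 (0.04 log units; within the scatter) and stays within the scatter. For compound 4 the estimated value is 68000 nM, with an expected range from 35000 nM to 130000 nM in this assay.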

Compound 4, half-maximal inhibitory concentration: 92000 nM
Estimate against measurement, compound 4: 1.4-fold (0.13 log units) below; the range from low to high includes it.
By their numbers in this assay, from the lowest: compounds 3, 2, 4 and 1 (each within the scatter of the next).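

In this assay, a further repeat of the change gives a 1.2-fold higher number from compound 3 to compound 4 (0.09 log units; within the scatter), and the double repeat gives a 1.1-fold higher number from compound 2 to compound 4 (0.03 log units; within the scatter). Going by these compounds alone, the lower numbers seen in the earlier steps therefore do not continue, with compound 4 going against that drift, and the series stays flat across this extension of the chain. The change reads alike on different cores: the same change on two cores in this assay, a 1.2-fold lower number (0.09 log units; within the scatter) from compound 1 to compound 2 and a 1.2-fold higher number (0.09 log units; within the scatter) from compound 3 to compound 4, 1.5-fold (0.18 log units) apart, within the scatter of two such steps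

Still open, on these data alone, is whether free hydroxyl groups in place of the methoxy groups would give a step beyond the scatter. The same question applies to a carboxylic acid or an amine at the chain end.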